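Swapping the Aminopyridine on a Spirocyclic Amide Core

A few compounds are considered here, and "the series" means these few. Any claim that something is new, unique, unknown or untested is made for them only; others in the source may bear on it.

Measured compounds:
Compound 1 `Cc1cc(C(F)(F)F)cc(NC[C@@H]2CC3(CC3)CN2C(=O)c2nc(C)sc2-c2ccccc2)n1` gives 7.8.
Compound 2 `Cc1ccc(-c2ncccn2)c(C(=O)N2CC3(CC3)C[C@H]2CNc2cc(C(F)(F)F)ccn2)c1` gives 7.3.
Compound 3 `Cc1ccc(OCc2ccccc2)c(C(=O)N2CC3(CC3)C[C@H]2CNc2ccc(C(F)(F)F)cn2)n1` gives 8.6.

All three were tested in a functional assay on CHO cells for antagonist activity at Orexin/Hypocretin receptor type 1 (Homo sapiens), read by FLIPR and calcium flux; on this read-out lower numbers stand for lower potency and higher numbers for higher potency (the scale is a negative logarithm). Compound 1 stands second highest among the three numbers: compound 2 sits lower than it by an amount beyond the usual scatter, and compound 3 sits higher than it by an amount also beyond the scatter. Compound 2 and compound 3 differ from compound 1 in more than one place, so neither gives a clean single step.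

Compound 4 `Cc1nc(C(=O)N2CC3(CC3)C[C@H]2CNc2ccc(C(F)(F)F)cn2)c(-c2ccccc2)s1` has not yet been measured. It keeps the core of compound 1 and changes only the aminopyridine: 5-(trifluoromethyl)pyridin-2-yl in place of 6-methyl-4-(trifluoromethyl)pyridin-2-yl on an amine nitrogen. For the measured compounds named here, the incoming group is the same one carried by compound 3, the highest of the measured numbers, while the only compound carrying a 4-(trifluoromethyl)pyridine, compound 2, gives the lowest.

On that basis a modest upward step is expected in this assay, though nothing in the measured set pins its size, and a change within the scatter cannot be ruled out. Compound 4 is estimated at 8, with a likely range from 7.3 to 8.7. This estimate means an expected step of a number 0.20 log units higher from compound 1 to compound 4 (within the scatter).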

Compound 4, negative logarithm of the antagonist equilibrium constant: 8.4
Compound 4: middle estimate off by 0.40 log units, on the low side; the measured number falls inside the stated range.
By their numbers in this assay, from the lowest: compound 2; then compound 1; then compounds 4 and 3 (each within the scatter of the next).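

In this assay, for the compounds shown here, this is the first comparison in the set that changes only one place: with the shared core held fixed, 5-(trifluoromethyl)pyridin-2-yl in place of 6-methyl-4-(trifluoromethyl)pyridin-2-yl on an amine nitrogen gives a number 0.60 log units higher from compound 1 to compound 4 (beyond the scatter). This shows that the pyridine on this amine nitrogen can shift the read-out by more than repeat measurements would, even though the group that enters differs from the one that leaves only by lacking the methyl and by carrying its trifluoromethyl at the 5 rather than the 4 position of the name. Nothing available here accounts for the size or direction of this step.

The single step combines those two differences, so the compounds shown cannot separate the effect of losing the methyl from that of moving the trifluoromethyl, and a plain 4-(trifluoromethyl)pyridin-2-yl on this same core would be the direct test. Going by these compounds, it also remains open how a nitrile or a chlorine in place of the trifluoromethyl would read, and whether the step would carry over to other amides.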